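Swapping a Cyclopropyl Amide for a tert-Butyl Amide

The source may report more compounds than this note shows. Statements on the series, on what has been measured and on what is new or still open speak of the compounds shown alone.

Measured compounds:
- compound 1 `CCCCCCCCCCCCn1nnc(C(C(=O)Nc2c(OC)ncnc2OC)c2ccccc2)n1` gives 13 nM in an assay on liver for inhibition of sterol O-acyltransferase 1 (Rattus norvegicus), using microsomes; on this read-out lower numbers stand for stronger inhibition and higher numbers for weaker inhibition
- compound 2 `CCCCCCCCCCCCn1nnc(C(C(=O)Nc2c(C)nn(C)c2C)c2ccccc2)n1` gives 13 nM in this assay
- compound 3 `CCCCCCCCCCCCn1nnc(C(C(=O)NC2CC2)c2ccccc2)n1` gives 244 nM in this assay

Compound 3 has the highest number of the three, standing a 19-fold higher number from compound 1 to compound 3 (1.27 log units; beyond the scatter) and a 19-fold higher number from compound 2 to compound 3 (1.27 log units; beyond the scatter), while no change at the digits printed from compound 1 to compound 2 (within the scatter). Compound 4 `CCCCCCCCCCCCn1nnc(C(C(=O)NC(C)(C)C)c2ccccc2)n1` carries tert-butyl in place of cyclopropyl on an amide-type nitrogen. For the measured compounds named here, no measured step swaps one small alkyl group for another on that nitrogen; the two large steps both concern an aromatic ring giving way to cyclopropyl, and compound 4 keeps a non-aromatic group there. The expected step is therefore small: a 1.2-fold higher number from compound 3 to compound 4 (0.09 log units; within the scatter), within the scatter. Compound 4 is estimated at 300 nM in this assay, with a range from 100 nM to 900 nM.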

Compound 4, half-maximal inhibitory concentration: 3350 nM
Estimate against measurement, compound 4: 11-fold (1.05 log units) below; measured number above the stated range.
By their numbers in this assay, from the lowest: compounds 1 and 2 (each within the scatter of the next); then compound 3; then compound 4.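

In this assay this amide-type nitrogen proves able to tell small non-aromatic groups apart: tert-butyl in place of cyclopropyl gives a 14-fold higher number from compound 3 to compound 4 (1.14 log units; beyond the scatter) and so is no neutral swap. The earlier steps shown here showed only aromatic rings giving way to cyclopropyl. Going from an aromatic ring straight to tert-butyl gives a 260-fold higher number from compound 2 to compound 4 (2.41 log units; beyond the scatter) and a 260-fold higher number from compound 1 to compound 4 (2.41 log units; beyond the scatter), the widest gaps in this set.

Nothing shown here accounts for the drop in inhibition. As far as these compounds go, whether isopropyl or cyclobutyl on that nitrogen would sit nearer compound 3 or compound 4 stays open.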